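Replacing piperidin-1-yl in compound 2

The source may hold more compounds than are shown below. What is called first, only, known or untested is meant among the compounds shown, and "the series" means these compounds.

Measured in a functional assay on MCF7 cells (Homo sapiens) for inhibition, read by MTT assay, with a stated time of 48 h; a lower number here means a stronger inhibitor, a higher number a weaker inhibitor:
compound 1 `COc1ccc(-c2nc3c(c(-c4ccccc4)nn3-c3ccccc3)c(-c3ccc(N4CCCCC4)cc3)c2C#N)cc1`: 2760 nM
compound 2 `N#Cc1c(-c2ccc(Cl)cc2)nc2c(c(-c3ccccc3)nn2-c2ccccc2)c1-c1ccc(N2CCCCC2)cc1`: 10600 nM
Not yet measured:
compound 3 `CN1CCN(c2ccc(-c3c(C#N)c(-c4ccc(Cl)cc4)nc4c3c(-c3ccccc3)nn4-c3ccccc3)cc2)CC1`

Of the two measured compounds, compound 2 has the higher number and is therefore the weaker inhibitor in this assay, at 10600 nM. Compound 3 differs from it by having 4-methylpiperazin-1-yl in place of piperidin-1-yl on an aromatic carbon. Going by the values given here, the only measured step is a 3.8-fold higher number from compound 1 to compound 2 (0.58 log units; beyond the scatter), with chloro in place of methoxy on an aromatic carbon. That modest step lies at another place on the molecule, so it bears only indirectly on the new change and gives no direction for it. Among the compounds with values here, no measured pair alters the piperidin-1-yl group. No step beyond the scatter is therefore expected, and the estimated step is a 1.2-fold lower number from compound 2 to compound 3 (0.07 log units; within the scatter). For compound 3 the expected value is 9000 nM, with an estimated range from 3000 nM to 25000 nM.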

Compound 3, half-maximal inhibitory concentration: 2710 nM
Compound 3: the middle estimate sits 3.3-fold (0.52 log units) above what was measured; the measured number lies below the stated range.
By their numbers in this assay, from the lowest: compounds 3 and 1 (each within the scatter of the next); then compound 2.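

Replacing piperidin-1-yl with 4-methylpiperazin-1-yl gives a 3.9-fold lower number from compound 2 to compound 3 (0.59 log units; beyond the scatter) in this assay and shows that this position, on an aromatic carbon of a six-membered aromatic ring of carbon only, can change the reading beyond the scatter. Going by these compounds alone, until now, the only measured change had been chloro in place of methoxy at another place on the molecule. No evidence is shown that explains this step.

The compounds shown do not separate the part played by the added ring nitrogen from that of its methyl, a question that an unsubstituted piperazin-1-yl or a morpholin-4-yl group at this position would address. They also leave open whether the same change would give a step of similar size with the methoxy group of compound 1 in place of the chloro group.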